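The source may hold more compounds than are shown below. What is called first, only, known or untested is meant among the compounds shown, and "the series" means these compounds.

The measured compounds:
Compound 1 `CCCN1CCCN(c2nc3ccccc3n2CCOCC)CC1` gives 8.4 nM in a functional assay on ileum for inhibition of histamine H1 receptor (Cavia porcellus); on this read-out lower numbers stand for stronger inhibition and higher numbers for weaker inhibition.
Compound 2 `CCCOCCn1c(N2CCN(C)CC2)nc2ccccc21` gives 20 nM in this assay.
Compound 3 `CCOCCn1c(N2CCN(C(c3ccccc3)c3ccccc3)CC2)nc2ccccc21` reaches only a limit in this assay, namely > 3000 nM.

Of the two numbers that are not limits, compound 2 stands at the higher one; compound 1 sits lower, and the gap between compound 1 and compound 2 lies beyond the usual scatter. Compound 3 is left aside here because its figure is a limit, (the limit of > 3000 nM in this assay, at which 1 of the 3 values shown sits).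

Compound 4 `COCCCn1c(N2CCN(C)CC2)nc2ccccc21` differs from compound 2 in one place: methoxymethyl in place of propoxy on a saturated chain carbon, two bonds along the chain from an aromatic nitrogen, in words methoxymethyl in place of propoxy on a saturated chain carbon, two bonds along the chain from an aromatic nitrogen. Among the compounds with values here, no pair of measured compounds differs by this change alone, and compound 1 carries a different amine as well as a different chain, so it offers no clean comparison. The chain keeps one ether oxygen and shortens by one carbon. The expected step from compound 2 to compound 4 in this assay is a 1.3-fold higher number from compound 2 to compound 4 (0.10 log units; within the scatter), no more than the scatter. Compound 4 is therefore expected to give 25 nM, in the range 8 nM to 80 nM.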

Compound 4, half-maximal inhibitory concentration: 860 nM
Compound 4: the middle estimate sits 34-fold (1.54 log units) below what was measured; the whole stated range lies below it.
By their numbers in this assay, from the lowest: compound 1; then compound 2; then compound 4. At a limit, above all of these: compound 3.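

In this assay, within the data shown here, the exchange of 2-propoxyethyl for 3-methoxypropyl on the shared core gives a 43-fold higher number from compound 2 to compound 4 (1.63 log units; beyond the scatter), the first step here that isolates this chain, and it shows that the read-out is highly sensitive to a small change at this place. Both groups have no net charge, no hydrogen-bond donors and one hydrogen-bond acceptor, so these counts do not separate them, and keeping an ether oxygen in the chain does not by itself preserve the number. No measurement shown here bears on the cause of this step.

The compounds shown leave open whether the shorter chain or the changed placement of its oxygen accounts for the step. A 2-ethoxyethyl or 4-methoxybutyl chain on the same core would help separate these two readings.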